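The compounds below may be only part of what the source reports. "The series", "measured", "known", "first", "only" and "open" are said of these compounds alone.

Compound 1 `COc1ccc(C2N=C(SCc3cccc(Cl)c3)NC(C)=C2C(=O)Nc2ccc(F)cc2)cc1OC` gives 10.8% in a functional assay on the whole organism (artery, strain albino) with Rattus norvegicus as the target, with a stated time of 120 min, at a dose of 10 mg/kg by the oral route; a lower number here means less inhibition, a higher number more inhibition at the dose given (going by the name of the read-out).
Compound 2 `COc1ccc(C2N=C(SCc3ccc(F)cc3)NC(C)=C2C(=O)Nc2ccc(F)cc2)cc1OC` gives 15.5% in this assay.
Compound 3 `CC1=C(C(=O)Nc2ccc(Br)cc2)C(c2ccc(Cl)cc2Cl)N=C(SCc2ccccc2)N1` gives 10.3% in this assay.

All three numbers lie within the usual scatter of one another, so compound 3 cannot be set apart from compound 1 or compound 2 on these data; its gap to compound 1 is smaller than its gap to compound 2, but neither gap counts as a real difference.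

Compound 4 `CC1=C(C(=O)Nc2ccc(Br)cc2)C(c2ccc(Cl)cc2Cl)N=C(SCc2ccc(Cl)cc2)N1` has not yet been measured. It differs from compound 3 in one place: chloro in place of hydrogen on an aromatic carbon.

For the measured compounds named here, the only measured step that resembles this change is a number 4.7 percentage points higher from compound 1 to compound 2 (within the scatter), where one halogen on the same benzyl ring was swapped for another and the number did not move beyond the scatter. Going by the values given here, that single comparison is the sole guide here, and it points to no step beyond the scatter in this assay either way. The step from compound 3 to compound 4 is therefore expected to be a number 1.7 percentage points higher from compound 3 to compound 4 (within the scatter). Compound 4 is estimated to give 12%, with a likely range from 2% to 25%.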

Compound 4, a percentage reported as inhibition, in the whole organism at one dose (the size of the read-out at that dose, not a potency): 17.5%
Compound 4: middle estimate off by 5.5 percentage points, on the low side; the range from low to high includes it.
By their numbers in this assay, from the lowest: compounds 3, 1, 2 and 4 (each within the scatter of the next).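

Chloro in place of hydrogen on the benzyl ring gives, in this assay, a number 7.2 percentage points higher from compound 3 to compound 4 (within the scatter). Unlike the earlier step of a number 4.7 percentage points higher from compound 1 to compound 2 (within the scatter), which swaps one halogenated benzyl ring for another, this step compares a halogen with plain hydrogen, and it shows that this aromatic carbon, para to a large group, can carry a chloro group with a result that still cannot be told apart from the unsubstituted benzyl compound. No measurement shown here explains the numbers of these compounds.

On these data alone, all four compounds carry only halogens or hydrogen on this benzyl ring, so what an amine or a carboxylic acid at this carbon would give remains open. Also open, as far as these compounds go, is whether a longer chain between the sulfur and this ring would move the number beyond the scatter.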